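The compounds below may be only part of what the source reports. "The series", "measured", "known", "first", "only" and "open" are said of these compounds alone.

In a physicochemical assay for activation, with a stated time of 60 min (on this read-out higher numbers stand for an effect only at larger amounts of compound and lower numbers for an effect already at smaller amounts), compound 1 `O=C1NC(=O)/C(=C\c2ccc(Cl)cc2)C2=C1CCCC2` gives 500 nM and shares the lowest number of the three measured compounds with compound 2 `COc1cc(/C=C2\C(=O)NC(=O)C3=C2CCCC3)cc(OC)c1OC` at 500 nM on the digits reported, so the two sit within the scatter of each other. Compound 3 `O=C1NC(=O)/C(=C\c2ccncc2)C2=C1CCCC2` reads much higher at 95000 nM and lies beyond the scatter from compound 1.

Compound 4 `O=C1NC(=O)/C(=C\c2ccc(C3CCCCC3)cc2)C2=C1CCCC2` has not yet been measured. The change cyclohexyl in place of chloro on an aromatic carbon puts cyclohexyl in place of chloro on an aromatic carbon, para to a large group.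

Among the measured compounds shown here, no measured pair isolates a change at this place, so any expectation is indirect. The aromatic ring of compound 2 is substituted differently from that of compound 1, yet compound 2 still reads 500 nM in this assay and stays level with it. On that basis a jump as wide as the gap to compound 3, which reads 95000 nM, is not expected, although the exchange of a single chlorine for a whole carbocycle leaves real uncertainty on the upper side. The expected step of a 1.8-fold higher number from compound 1 to compound 4 (0.26 log units; within the scatter) is a small rise that stays within the scatter. For compound 4 the estimated value is 900 nM (expected range 200 nM to 5000 nM).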

Compound 4, half-maximal effective concentration: 121000 nM
Compound 4: middle estimate off by 130-fold (2.13 log units), on the low side; the measured number lies above the stated range.
By their numbers in this assay, from the lowest: compounds 1 and 2 (each within the scatter of the next); then compounds 3 and 4 (each within the scatter of the next).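

In this assay, this place on an aromatic carbon, para to a large group, is not indifferent to what stands on it: cyclohexyl in place of chloro gives a 240-fold higher number from compound 1 to compound 4 (2.38 log units; beyond the scatter), the only step shown that isolates a change at a single place. The exchange replaces 1 heavy atom, a chlorine, with 6 heavy atoms, all carbon, in one six-membered non-aromatic ring, while the counts of hydrogen-bond donors and acceptors stay at 0 and neither group carries a net charge. The compounds and measurements shown offer nothing that accounts for a step of this size, and a single pair cannot assign it to any one feature of the cyclohexyl group.

As far as these compounds go, it remains open how the read-out moves between these two groups, for instance with a methyl group, a short propyl chain or an unsaturated phenyl ring at the same place. Also open, from the compounds shown here alone, is whether an amine or a carboxylic acid carried on a cyclohexyl ring at this place would keep the number close to that of compound 4 or bring it back towards that of compound 1.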